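This account rests on a few compounds, and the source may have more. Where it says the series, first, only, none or still open, it means among the compounds named here.

Among the compounds with values here, in a functional assay on SW480 cells (Homo sapiens) for cytotoxicity, read by MTT assay, with a stated time of 48 h (a lower number here means a stronger inhibitor, a higher number a weaker inhibitor), compound 1 (`COc1cc([C@@H]2C[C@]2(CO)C(=O)Nc2ccccc2Cl)cc(OC)c1OC`) gives 13200 nM as the only single number among the three compounds tested so far. Compound 2 (`CCOC(=O)[C@@]1(C(=O)Nc2ccccc2)C[C@@H]1c1cc(OC)c(OC)c(OC)c1`) gives > 100000 nM as a limit of the assay and not a number. Compound 3 (`CCOC(=O)C1(C(=O)NCc2ccc(F)cc2)CC1c1cc(OC)c(OC)c(OC)c1`) has two entries, recorded as 34100 nM; 28400 nM (2 entries) in the same test.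

Compound 4 (`COc1cc([C@@H]2C[C@]2(CO)C(=O)NCc2ccc(C)cc2)cc(OC)c1OC`) has not yet been measured. Its difference from compound 1 is counted as 4-methylbenzyl in place of 2-chlorophenyl on an amide-type nitrogen and amounts to 4-methylbenzyl in place of 2-chlorophenyl on an amide-type nitrogen.

Within the data shown here, no measured pair isolates this change, so the expectation rests on little. Compound 3 also carries a benzyl group on an amide-type nitrogen and gives 34100 nM; 28400 nM (2 entries) here, so a modest move toward weaker inhibition is expected, not far beyond the scatter. The expected change is a 1.7-fold higher number from compound 1 to compound 4 (0.22 log units; within the scatter) in this assay on this reasoning. For compound 4 the estimated value is 22000 nM with an expected range of 9000 nM to 55000 nM before any measurement.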

Compound 4, half-maximal inhibitory concentration: 26800 nM
Compound 4: middle estimate off by 1.2-fold (0.09 log units), on the low side, within the range that was stated.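

Within the data shown here, compound 1 and compound 4 form the first pair here that differs in one place, so they give the first direct reading of this amide-type nitrogen in this assay, with a 2.0-fold higher number from compound 1 to compound 4 (0.31 log units; beyond the scatter). The step is modest, and the swap leaves one six-membered aromatic ring of carbon only in the substituent, so replacing 2-chlorophenyl with 4-methylbenzyl shifts the value without abolishing the measured activity. However, the swap removes the chlorine and brings in carbon at once, so this single step cannot apportion the shift between those parts, and nothing measured here gives a cause for it.

The compounds shown leave open how much of the step would remain with a plain benzyl or a 2-chlorobenzyl group on this nitrogen. They also leave open how a carboxylic acid or an amine on the ring would read in this assay.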